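This account rests on a few compounds, and the source may have more. Where it says the series, first, only, none or still open, it means among the compounds named here.

Values below are from a functional assay on OVCAR-4 cells (Homo sapiens) for inhibition, read by sulforhodamine B assay, with a stated time of 48 h; a lower number here means a stronger inhibitor of growth, a higher number a weaker inhibitor of growth.

Measured compounds:
compound 1, `COc1cc(-c2cc(/C=C/C(=O)c3ccc(N)cc3)[nH]n2)cc(OC)c1OC`: 5440 nM
compound 2, `COc1ccc(-c2cc(/C=C/C(=O)c3ccc(N)cc3)[nH]n2)cc1OC`: 15800 nM
compound 3, `COc1cc(C(=O)/C=C/c2cc(-c3cc(OC)c(OC)c(OC)c3)n[nH]2)cc(OC)c1OC`: 2760 nM

Compound 2 differs from compound 1 by one change, (hydrogen in place of methoxy on an aromatic carbon). In this assay this change gives a 2.9-fold higher number from compound 1 to compound 2 (0.46 log units; beyond the scatter), a modest step but beyond the usual scatter.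

Compound 3 carries a different core; the difference between the two cores is not broken down here. In this assay compound 3 and compound 1 sit within the usual scatter of each other, while the gap from compound 3 to compound 2 lies beyond it.

Compound 4, `COc1ccc(-c2cc(/C=C/C(=O)c3cc(OC)c(OC)c(OC)c3)[nH]n2)cc1OC`, is not yet measured. It differs from compound 3 by hydrogen in place of methoxy on an aromatic carbon. This is the same change as that made from compound 1 to compound 2, and the surroundings of the place are described in the same words in both cases, so the pairs differ only in the core on which the change is made.

The expectation for compound 4 rests on two points: the step of a 2.9-fold higher number from compound 1 to compound 2 (0.46 log units; beyond the scatter), and the starting value of compound 3, 2760 nM. On that basis the step from compound 3 to compound 4 is expected to be about a 2.9-fold higher number from compound 3 to compound 4 (0.46 log units; beyond the scatter) in this assay, of the same sign and similar size as the earlier one. Compound 4 is therefore estimated at 8000 nM, with a likely range from 3500 nM to 18000 nM.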

Compound 4, concentration for total growth inhibition: 7170 nM
Estimate against measurement, compound 4: 1.1-fold (0.05 log units) above; measured number inside the range.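

In this assay, hydrogen in place of methoxy gives a 2.6-fold higher number from compound 3 to compound 4 (0.41 log units; beyond the scatter), so the change keeps its direction on the core of compound 3 and remains a modest step beyond the usual scatter. Set beside the earlier step, the size of the change also holds from one core to the other: the same change on two cores in this assay, a 2.9-fold higher number (0.46 log units; beyond the scatter) from compound 1 to compound 2 and a 2.6-fold higher number (0.41 log units; beyond the scatter) from compound 3 to compound 4, 1.1-fold (0.05 log units) apart, within the scatter of two such steps. This supports carrying the change between these two cores only, as it rests on a single pair for each core and does not show that the step would hold on any other core or explain how it arises.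

The compounds shown hold only methoxy and hydrogen at this place, so it stays open how a hydroxyl, a fluorine or an ethoxy group there would compare with them. Also open, going by these compounds, is whether the same step would appear on a core carrying a carboxylic acid or an amide in place of the amine of compound 1 and compound 2, or in a series where the ketone and its double bond are replaced by a longer chain.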